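The source may hold more compounds than are shown below. What is called first, only, known or untested is meant among the compounds shown, and "the series" means these compounds.

Measured compounds:
compound 1 `N=C(NCc1ccccc1)[C@@H]1CCC(=O)N1Cc1ccccc1`, 16.6%
compound 2 `N=C(NCc1ccc(O)cc1)[C@@H]1CCC(=O)N1Cc1ccccc1`, 19.8%
compound 3 `N=C(NCc1ccccc1)[C@@H]1CCC(=O)N1Cc1ccccc1[N+](=O)[O-]`, 10.1%

All three were run in a functional assay on SH-SY5Y cells (Homo sapiens) for cytotoxicity, read by MTT assay, with stated times of 8 h, 30 min and 12 h, tested at 0.05 uM; on this read-out higher numbers stand for a stronger effect at the one concentration tested and lower numbers for a weaker effect. Compound 3, at 10.1%, carries the lowest of the three numbers on paper, but no gap beyond the scatter separates it from the others: the step of a number 6.5 percentage points lower from compound 1 to compound 3 (within the scatter) is within the scatter, and compound 2 at 19.8% sits within the scatter of compound 3 as well. On these numbers the three compounds cannot be told apart.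

Compound 4 `N=C(NCc1ccc(O)cc1)[C@@H]1CCC(=O)N1Cc1ccccc1[N+](=O)[O-]` is the next member and has not yet been measured. It differs from compound 3 by hydroxy in place of hydrogen on an aromatic carbon. For the measured compounds named here, the one measured step that bears on this change is a number 3.2 percentage points higher from compound 1 to compound 2 (within the scatter), the same hydroxy in place of hydrogen on an aromatic carbon, made on the compound without the nitro group; it was within the scatter. Nothing else in the set speaks to the change. The expectation for compound 4 is therefore a step of about a number 2.9 percentage points higher from compound 3 to compound 4 (within the scatter) in this assay, which is no step beyond the scatter.

Compound 4 is estimated at 13% in this assay, with a range from 4% to 23%.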

Compound 4, a percentage reported as activity, at one concentration (the size of the read-out at that concentration, not a potency): 20%
Compound 4: middle estimate off by 7 percentage points, on the low side, within the range that was stated.
By their numbers in this assay, from the lowest: compounds 3, 1, 2 and 4 (each within the scatter of the next).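

In this assay the hydroxy change on the aromatic carbon para to a large group now has a second reading on a different core, a number 9.9 percentage points higher from compound 3 to compound 4 (within the scatter), and the two readings agree: the same change on two cores in this assay, a number 3.2 percentage points higher (within the scatter) from compound 1 to compound 2 and a number 9.9 percentage points higher (within the scatter) from compound 3 to compound 4, 6.7 percentage points apart, within the scatter of two such steps

The nitro change also gains a second reading, now on the core already carrying hydroxy, a number 0.2 percentage points higher from compound 2 to compound 4 (within the scatter), and it too agrees with the first: the same change on two cores in this assay, a number 6.5 percentage points lower (within the scatter) from compound 1 to compound 3 and a number 0.2 percentage points higher (within the scatter) from compound 2 to compound 4, 6.7 percentage points apart, within the scatter of two such steps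

Neither change has yet given a step beyond the scatter on either core, so compounds 1, 2, 3 and 4 cannot be told apart at the one concentration tested, and the two groups show no measurable dependence on each other.

Still open, as far as these compounds go, is whether any other group at this position, such as methoxy, an amine or a carboxylic acid, would give a step beyond the scatter. A reading at one concentration gives no potency, so these compounds also leave open how the four would compare across a range of concentrations.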